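The compounds below may be only part of what the source reports. "The series", "measured", "known", "first", "only" and "open" are said of these compounds alone.

compound 1 `COc1cc(/C=C/C(=O)c2cccc(-n3cc(-c4ccccc4)[nH]c3=O)c2)ccc1O`: 2700 nM
compound 2 `O=C(/C=C/c1cccc(O)c1)c1cccc(-n2cc(-c3ccccc3)[nH]c2=O)c1`: 4240 nM

Of the compounds shown here, two have been measured in a functional assay on T47D cells (Homo sapiens) for inhibition; on this read-out lower numbers stand for stronger inhibition of growth and higher numbers for weaker inhibition of growth. For the measured compounds named here, compound 1 stands at one end of this pair, but the only step between them, a 1.6-fold higher number from compound 1 to compound 2 (0.20 log units; within the scatter), is within the scatter, so the two numbers cannot be told apart with confidence. That step swaps the ring on the double-bonded chain, not the ring on the shared core.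

Compound 3 `COc1ccc(-c2cn(-c3cccc(C(=O)/C=C/c4ccc(O)c(OC)c4)c3)c(=O)[nH]2)cc1` differs from compound 1 at that other ring: methoxy in place of hydrogen on an aromatic carbon, so that the phenyl on the core becomes 4-methoxyphenyl. Going by the values given here, no measured step touches this position, and the one step known, a 1.6-fold higher number from compound 1 to compound 2 (0.20 log units; within the scatter), was within the scatter. The change is small, and nothing in the data points in either direction, so the expected step of no change at the digits printed from compound 1 to compound 3 (within the scatter) is none beyond the scatter. Compound 3 is therefore estimated at 2700 nM in this assay, with a range from 1000 nM to 7500 nM.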

Compound 3, concentration for 50% growth inhibition: 3600 nM
The estimate for compound 3 lay 1.3-fold (0.12 log units) below the measured number, and the stated range covers the measured number.
By their numbers in this assay, from the lowest: compounds 1, 3 and 2 (each within the scatter of the next).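

In this assay, for the compounds shown here, the phenyl on the shared core is varied for the first time here, and turning it into 4-methoxyphenyl gives a 1.3-fold higher number from compound 1 to compound 3 (0.12 log units; within the scatter) so compound 1 and compound 3 cannot be told apart. At this place, para to a large group, adding methoxy with its 2 heavy atoms therefore leaves no change that these numbers can resolve, whereas the earlier pair spoke only to the ring on the double-bonded chain. Nothing available offers an explanation for this result.

One small group at one place cannot show how far this tolerance extends. An amine, a carboxylic acid or a longer chain such as butoxy on the same ring might stay within the scatter or move the number beyond it.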